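Swapping chloro for methoxy on a carbamate pyrazole series

The source may report more compounds than this note shows. Statements on the series, on what has been measured and on what is new or still open speak of the compounds shown alone.

Measured compounds:
compound 1, `CCOC(=O)c1cc(-c2cccc(OC(=O)NC3CCCCC3)c2)nn1-c1ccc(Cl)cc1`, 353 nM in an assay on isolated protein for inhibition of Fatty-acid amide hydrolase 1 (Homo sapiens), read by fluorescence, with a stated time of 30 min; on this read-out higher numbers stand for weaker inhibition and lower numbers for stronger inhibition
compound 2, `CCOC(=O)c1cc(-c2cccc(OC(=O)NC3CCCCC3)c2)nn1-c1ccc(OC)cc1`, 407 nM
compound 3, `CCOC(=O)c1cc(-c2ccc(OC(=O)NC3CCCCC3)cc2)nn1-c1ccc(Cl)cc1`, 586 nM

Compounds 1 and 2 share one core; compound 3 is built from the same atoms joined differently, and the difference between the two cores is not broken down here. Compound 1 and compound 2 differ by methoxy in place of chloro on an aromatic carbon, and in this assay that change gave a 1.2-fold higher number from compound 1 to compound 2 (0.06 log units; within the scatter), so the two values are effectively the same.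

Compound 4, `CCOC(=O)c1cc(-c2ccc(OC(=O)NC3CCCCC3)cc2)nn1-c1ccc(OC)cc1`, has not yet been measured in this assay. It differs from compound 3 by methoxy in place of chloro on an aromatic carbon, the same change seen between compound 1 and compound 2 at the same place.

Because the earlier step of a 1.2-fold higher number from compound 1 to compound 2 (0.06 log units; within the scatter) stayed within the scatter, the expectation is that compound 4 will sit close to compound 3, with an estimated step of a 1.2-fold higher number from compound 3 to compound 4 (0.06 log units; within the scatter). Compound 4 is therefore expected to give about 680 nM in this assay, with a likely range from 400 nM to 1200 nM. One earlier pair is a thin basis, so the range is kept wide.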

Compound 4, half-maximal inhibitory concentration: 159 nM
For compound 4 the middle estimate is 4.3-fold (0.63 log units) above the measured one; measured number below the stated range.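

On the core of compound 3, methoxy in place of chloro gave a 3.7-fold lower number from compound 3 to compound 4 (0.57 log units; beyond the scatter) in this assay and so made a measurable difference, whereas the same swap on the core of compound 1 left the value effectively unchanged: the same change on two cores in this assay, a 1.2-fold higher number (0.06 log units; within the scatter) from compound 1 to compound 2 and a 3.7-fold lower number (0.57 log units; beyond the scatter) from compound 3 to compound 4, 4.2-fold (0.63 log units) apart, beyond the scatter of two such steps. In these two pairs, then, the effect of going from 4-chlorophenyl to 4-methoxyphenyl depends on the core that carries it, and a step measured on one core was not a safe guide to the step on the other. This does not show why the two cores respond differently, and two pairs cannot set a rule for the wider series.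

The compounds shown leave open how an amine or a hydroxyl group at this same place would behave on each core, and whether the two cores would again part ways. They also leave open whether the difference between the cores would persist with a carboxylic acid in place of the ethyl ester.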